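Compound 2 trades its aromatic side ring for a small ring

The source may hold more compounds than are shown below. What is called first, only, known or untested is meant among the compounds shown, and "the series" means these compounds.

In an ADME assay on MDCK cells (Canis lupus familiaris) for permeability, read by LC-MS, with a stated time of 90 min, tested at 2 uM (on this read-out lower numbers stand for lower permeability and higher numbers for higher permeability), compound 2 (`COc1cc(C)[nH]c(=O)c1CN1CCc2c(Cl)cc(-c3c(C)noc3C)c(Cl)c2C1=O`) gives 11 10^-6 cm/s as a single entry. Compound 1 (`COC(c1cc(Cl)c2c(c1Cl)C(=O)N(Cc1c(C)cc(C)[nH]c1=O)CC2)C1CCOC1`) gives 17.1 10^-6 cm/s; 18.7 10^-6 cm/s; 15.4 10^-6 cm/s; 18.4 10^-6 cm/s (4 entries) over repeated entries, and compound 3 (`COC(c1cc(Cl)c2c(c1Cl)C(=O)N(Cc1c(C)cc(C)[nH]c1=O)CC2)C1CCOCC1`) gives 13.3 10^-6 cm/s; 16.5 10^-6 cm/s (2 entries) over repeated entries too. These numbers all lie within the usual scatter of one another, so compound 2 stands level with the other two.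

Compound 4 (`COc1cc(C)[nH]c(=O)c1CN1CCc2c(Cl)cc([C@H](O)C3COC3)c(Cl)c2C1=O`) differs from compound 2 in one place on an aromatic carbon: a group of 6 heavy atoms (4 carbon, 2 oxygen; one four-membered non-aromatic ring with 1 hetero atom) in place of a group of 7 heavy atoms (5 carbon, 1 nitrogen, 1 oxygen; one five-membered aromatic ring with 2 hetero atoms), on an aromatic carbon describes the swap. The 3,5-dimethyl-1,2-oxazol-4-yl group leaves, and a group with a four-membered non-aromatic ring and a defined stereocentre enters. Only the entering group has a hydrogen-bond donor. Among the measured compounds shown here, no measured pair here shows what such a swap does, so the size of the step is a judgement. A fall somewhat beyond the scatter is expected in this assay for this swap. The estimated size is a 2.4-fold lower number from compound 2 to compound 4 (0.39 log units; beyond the scatter) on this reasoning. Compound 4 is expected at 4.5 10^-6 cm/s (estimated range 1.8 10^-6 cm/s to 10 10^-6 cm/s).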

Compound 4, apparent permeability: 0.7 10^-6 cm/s
Beside the measured number, compound 4's estimate is 6.4-fold (0.81 log units) above it; the measured number lies below the stated range.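

Among the compounds shown here, the earlier compounds offered no step at this position, so this is the first sign that the group on this aromatic carbon can move the read-out strongly: in this assay, the swap gives a 16-fold lower number from compound 2 to compound 4 (1.20 log units; beyond the scatter). The step is large compared with the spread of repeated entries for a single compound, seen in the several entries of compound 1 in this assay, 17.1 10^-6 cm/s; 18.7 10^-6 cm/s; 15.4 10^-6 cm/s; 18.4 10^-6 cm/s (4 entries) The swap removes a five-membered aromatic ring without a hydrogen-bond donor and brings in a group with a four-membered non-aromatic ring and a hydrogen-bond donor, yet this single pair cannot show which of these differences matters.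

The compounds shown leave open whether the same four-membered ring without the hydrogen-bond donor would keep the higher number, and what the opposite stereocentre would give. They also leave open how a phenyl ring or an amine would read on this aromatic carbon.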